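A few compounds are considered here, and "the series" means these few. Any claim that something is new, unique, unknown or untested is made for them only; others in the source may bear on it.

Compound 1, `CNC(=O)c1cc(C(=O)N[C@H]2CC[C@H](O)CC2)c([C@@H](C)c2cccc(Cl)c2)o1`, is the starting point. Among the measured compounds shown here, in a physicochemical assay for lipophilicity (on this read-out higher numbers stand for higher lipophilicity and lower numbers for lower lipophilicity), compound 1 gives 3.5, the higher of the two numbers measured so far. For the measured compounds named here, the only other measured compound, compound 2, `CC(=O)Nc1c(F)cc(C(=O)N[C@H]2CC[C@H](O)CC2)cc1O[C@@H](C)c1ccccc1`, is built on a different scaffold; in this assay compound 2 gives 2.8, a value that sits below compound 1 by a gap beyond the usual scatter.

The compound not yet measured is compound 3, `CNC(=O)c1cc(C(=O)N[C@H]2CC[C@H](O)CC2)c([C@@H](C)c2ccccc2)o1`. Compared with compound 1 it carries one change: hydrogen in place of chloro on an aromatic carbon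

Going by the values given here, no step between two measured compounds that differ only in this way is available here, so the size of the effect must be estimated from the nature of the change alone. A downward step from compound 1 to compound 3 is expected, of a size that is clearly beyond the scatter, a number 0.70 log units lower from compound 1 to compound 3 (beyond the scatter). For compound 3 the expected result in this assay is 2.8, with a likely range from 2.4 to 3.2.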

Compound 3, distribution coefficient: 2.8
Estimate against measurement, compound 3: no gap at the digits printed, within the range that was stated.
By their numbers in this assay, from the lowest: compounds 2 and 3 (each within the scatter of the next); then compound 1.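

Among the compounds shown here, replacing the chloro group with hydrogen, while the rest of the molecule stays the same, gives the first comparison in this assay that isolates a single place: the result is a number 0.70 log units lower from compound 1 to compound 3 (beyond the scatter) and it comes from the loss of one heavy atom. Compound 2 sits on a different scaffold, so it could not reveal what this one chlorine atom contributes on the shared core. Nothing available explains how this single atom produces a shift of this size.

The compounds shown leave open how other groups on this aromatic carbon, such as fluoro, methyl or methoxy, would compare with chloro and hydrogen in this assay. They also leave open whether the same replacement would give a similar step on a different core.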